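The compounds below may be only part of what the source reports. "The series", "measured", "known", "first", "only" and "open" are said of these compounds alone.

Measured so far in a functional assay on Jurkat cells (Homo sapiens) for inhibition, read by CCK-8 assay, with a stated time of 48 h; a higher number here means a weaker inhibitor of growth, a lower number a stronger inhibitor of growth:

- compound 1 `COc1ccccc1CNc1nc(Nc2ccc(N3CCN(C)CC3)cn2)ncc1Cl` gives 10800 nM
- compound 2 `Cc1ccc(Nc2nc(Nc3ccc(N4CCN(C)CC4)cn3)ncc2Cl)cc1` gives 30900 nM
- compound 3 `CN1CCN(c2ccc(Nc3ncc(Cl)c(Nc4ccc(C(C)(C)C)cc4)n3)nc2)CC1` gives "not determined" (no result reported)

No number was reported for compound 3. It therefore stands nowhere on the scale. Compound 4 `COc1cccc(Nc2nc(Nc3ccc(N4CCN(C)CC4)cn3)ncc2Cl)c1` has yet to be measured in this assay. It carries 3-methoxyphenyl in place of the 4-(tert-butyl)phenyl of compound 3, on a nitrogen on an aromatic ring (3-methoxyphenyl in place of 4-(tert-butyl)phenyl on a nitrogen on an aromatic ring).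

Without a starting value, this change cannot be sized as a step from compound 3, and no direction can be given for it. For the measured compounds named here, only one measured step bears on it, and only indirectly. That step, a 2.9-fold higher number from compound 1 to compound 2 (0.46 log units; beyond the scatter), is a change on the same kind of nitrogen, with 4-methylphenyl replacing 2-methoxybenzyl. It is modest, which suggests that changes at this place may not move the number very far. Compound 2, at 30900 nM, also has a substituted phenyl group there, so it is the better guide for compound 4, and a value in the same general region is expected. Going by the values given here, the data hold only two numbers, so the range must stay wide.

The estimated value for compound 4 is 20000 nM, with an expected range from 7000 nM to 50000 nM.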

Compound 4, concentration for 50% growth inhibition: 15800 nM
Beside the measured number, compound 4's estimate is 1.3-fold (0.10 log units) above it; the range from low to high includes it.
By their numbers in this assay, from the lowest: compounds 1, 4 and 2 (each within the scatter of the next, the first and the last beyond it).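

In this assay, putting 3-methoxyphenyl on this nitrogen in place of 4-methylphenyl gives a 2.0-fold lower number from compound 2 to compound 4 (0.29 log units; within the scatter) and putting it in place of 2-methoxybenzyl gives a 1.5-fold higher number from compound 1 to compound 4 (0.17 log units; within the scatter) at the same place. Compound 4 therefore cannot be told apart from either of the other two compounds, although the earlier step of a 2.9-fold higher number from compound 1 to compound 2 (0.46 log units; beyond the scatter) does lie beyond the scatter, so the three measured groups on this nitrogen fill one connected stretch of the scale rather than forming separate levels. Nothing measured here explains why these groups give such similar numbers.

On these data alone, compound 3 has no number, so any step between it and compound 4 cannot be read, and the effect of 4-(tert-butyl)phenyl at this place stays unknown. As far as these compounds go, it also remains open whether a group of a different kind on this nitrogen, such as a phenyl ring carrying an amine or a carboxylic acid, or a longer chain in place of the ring, would move the number further than these three groups do.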